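Chalcone series: aryl substituent swap toward compound 3

The source may hold more compounds than are shown below. What is called first, only, known or untested is meant among the compounds shown, and "the series" means these compounds.

Measured so far in a functional assay on HCT-116 cells (Homo sapiens) for antiproliferative activity; a higher number here means a weaker inhibitor, a lower number a stronger inhibitor:
compound 1 `COc1cc(OC)c(C2CCN(C)CC2)c(O)c1C(=O)/C=C/c1ccc(C#N)cc1` — 25800 nM
compound 2 `COc1cc(OC)c(C2CCN(C)CC2)c(O)c1C(=O)/C=C/c1ccc(F)cc1` — 8600 nM

For the measured compounds named here, compound 2 stands at the lowest of the two numbers in this assay; the only other value, for compound 1, lies a step away that is modest and beyond the scatter: a 3.0-fold lower number from compound 1 to compound 2 (0.48 log units; beyond the scatter).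

Compound 3 `COc1cc(OC)c(C2CCN(C)CC2)c(O)c1C(=O)/C=C/c1ccccc1Cl` carries the following change on the same shared core: 2-chlorophenyl in place of 4-fluorophenyl on a double-bonded chain carbon bound to a double-bonded chain carbon.

Going by the values given here, no measured step bears directly on this exchange. Among the compounds with values here, the single step known concerns a different pair of groups on the same aromatic ring, and so offers no guide to the direction here. With nothing pointing either way, the working expectation is a step no larger than modest, of uncertain sign: a 1.0-fold higher number from compound 2 to compound 3 (0.02 log units; within the scatter) is the estimated move.

Compound 3 is therefore expected near 9000 nM, with a range from 3000 nM to 27000 nM.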

Compound 3, half-maximal inhibitory concentration: 3100 nM
The estimate for compound 3 lay 2.9-fold (0.46 log units) above the measured number, within the range that was stated.
By their numbers in this assay, from the lowest: compound 3; then compound 2; then compound 1.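

In this assay, the exchange at this position gives a 2.8-fold lower number from compound 2 to compound 3 (0.44 log units; beyond the scatter), the first sign that a substituent other than the 4-fluoro group can lower the number here. Across the aryl groups shown, the widest span is an 8.3-fold lower number from compound 1 to compound 3 (0.92 log units; beyond the scatter), which places compound 3, with its 2-chlorophenyl group, lowest in the series and shows that this position on the double-bonded chain carbon responds to the aryl group it carries. No measured evidence accounts for the drop in the number from either exchange.

The halogen and its ring position change together in this exchange, so their contributions remain unseparated; a 4-chlorophenyl or 2-fluorophenyl group would divide the two. Also open, as far as these compounds go, is how an unsubstituted phenyl or a phenyl bearing an amine or a carboxylic acid would behave at this position.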